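The source may report more compounds than this note shows. Statements on the series, on what has been measured and on what is new or still open speak of the compounds shown alone.

Three compounds measured so far in a functional assay on Bel7402/5-FU cells (Homo sapiens) for antiproliferative activity, read by MTT assay, with a stated time of 72 h; on this read-out lower numbers stand for stronger inhibition and higher numbers for weaker inhibition

- compound 1 `C=C1C(=O)O[C@H]2[C@H]1CC/C(COC(=O)Cn1cc(F)c(=O)n(Cc3ccc(F)cc3)c1=O)=C\CC[C@@]1(C)O[C@@H]21` gives 1140 nM
- compound 2 `C=C1C(=O)O[C@H]2[C@H]1CC/C(COC(=O)Cn1cc(F)c(=O)n(Cc3c(F)cccc3F)c1=O)=C\CC[C@@]1(C)O[C@@H]21` gives 4980 nM
- compound 3 `C=C1C(=O)O[C@H]2[C@H]1CC/C(COC(=O)Cn1cc(F)c(=O)n(Cc3ccc(F)c(F)c3)c1=O)=C\CC[C@@]1(C)O[C@@H]21` gives 4480 nM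

Compound 3 belongs to the upper pair of these numbers, and the gap within that pair is only a 1.1-fold lower number from compound 2 to compound 3 (0.05 log units; within the scatter). Compound 1 has the lowest number, and two modest steps lead away from it: a 4.4-fold higher number from compound 1 to compound 2 (0.64 log units; beyond the scatter) and a 3.9-fold higher number from compound 1 to compound 3 (0.59 log units; beyond the scatter). Compound 4 `C=C1C(=O)O[C@H]2[C@H]1CC/C(COC(=O)Cn1cc(F)c(=O)n(Cc3cc(F)ccc3F)c1=O)=C\CC[C@@]1(C)O[C@@H]21` has the same atoms as compound 3, joined differently, with 2,5-difluorophenyl in place of 3,4-difluorophenyl on a saturated chain carbon bound to an aromatic nitrogen on a saturated chain carbon bound to an aromatic nitrogen. Going by the values given here, exchanging one difluorophenyl for another made no difference beyond the scatter in the only such pair measured, a 1.1-fold lower number from compound 2 to compound 3 (0.05 log units; within the scatter), so a similarly small change is expected here. The expected step in this assay is a 1.1-fold lower number from compound 3 to compound 4 (0.05 log units; within the scatter). The estimate for compound 4 is 4000 nM, with an expected range of 1800 nM to 8000 nM.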

Compound 4, half-maximal inhibitory concentration: 4610 nM
The estimate for compound 4 lay 1.2-fold (0.06 log units) below the measured number, within the range that was stated.
By their numbers in this assay, from the lowest: compound 1; then compounds 3, 4 and 2 (each within the scatter of the next).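

In this assay, a third difluorophenyl pattern gives the same picture, with no change beyond the scatter: a 1.0-fold higher number from compound 3 to compound 4 (0.01 log units; within the scatter) and a 1.1-fold lower number from compound 2 to compound 4 (0.03 log units; within the scatter). All three difluorophenyl compounds stay apart from the 4-fluorophenyl compound, as in a 4.0-fold higher number from compound 1 to compound 4 (0.61 log units; beyond the scatter), so among these four the choice of difluorophenyl matters little compared with leaving 4-fluorophenyl. Nothing available explains this difference.

Still open, going by these compounds, is whether the second fluorine alone accounts for the gap. A phenyl without fluorine, or one carrying chlorine or methoxy instead, could show how far this position tolerates change.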